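Benzoyl in place of acetyl on the shared core

This account rests on a few compounds, and the source may have more. Where it says the series, first, only, none or still open, it means among the compounds named here.

The measured compounds:
compound 1, `CC(=O)Nc1c(C(O)(C(F)(F)F)C(F)(F)F)ccc2ccccc12`, 18 nM;
compound 2, `O=C(Nc1c(C(O)(C(F)(F)F)C(F)(F)F)ccc2ccccc12)C1CC1`, 751 nM;
compound 3, `O=C(Nc1ccc(Cl)cc1)Nc1c(C(O)(C(F)(F)F)C(F)(F)F)ccc2ccccc12`, 276 nM.

In an assay on LtK cells with ATP-sensitive inward rectifier potassium channel 11 (Homo sapiens) as the target (on this read-out higher numbers stand for an effect only at larger amounts of compound and lower numbers for an effect already at smaller amounts), compound 1 gives the lowest number of the three. Its nearest neighbour on that read-out is compound 3, with a 15-fold higher number from compound 1 to compound 3 (1.19 log units; beyond the scatter), and the furthest is compound 2, with a 42-fold higher number from compound 1 to compound 2 (1.62 log units; beyond the scatter). Both steps are beyond the scatter and both run in the same direction: each enlargement of the methyl on the carbonyl carbon gave a higher number.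

Compound 4, `O=C(Nc1c(C(O)(C(F)(F)F)C(F)(F)F)ccc2ccccc12)c1ccccc1`, is not yet measured. It differs from compound 1 in one place: phenyl in place of methyl on a carbonyl carbon. The two measured steps from compound 1 bear directly on this change, since each replaces the same methyl on the carbonyl carbon with a larger group, and each gave a large rise in this assay. A rise beyond the scatter is therefore expected here too, and compound 4 is estimated at 500 nM, within 150 nM to 2000 nM, which means an expected step of a 28-fold higher number from compound 1 to compound 4 (1.44 log units; beyond the scatter).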

Compound 4, half-maximal effective concentration: 44 nM
For compound 4 the middle estimate is 11-fold (1.06 log units) above the measured one, outside the stated range (below it).
By their numbers in this assay, from the lowest: compound 1; then compound 4; then compound 3; then compound 2.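

In this assay, going by these compounds alone, the step to phenyl, a 2.4-fold higher number from compound 1 to compound 4 (0.39 log units; beyond the scatter), is much smaller than the earlier steps away from methyl, so replacing the methyl on the carbonyl carbon with a larger group need not bring a large rise. The position also separates ring-bearing groups sharply, with a 17-fold lower number from compound 2 to compound 4 (1.23 log units; beyond the scatter) and a 6.3-fold lower number from compound 3 to compound 4 (0.80 log units; beyond the scatter), so the presence of a ring alone does not set the number, though compound 1 still gives the lowest number of the four. Nothing available explains why phenyl is tolerated so much better than cyclopropyl or (4-chlorophenyl)amino.

The compounds shown leave open whether the chlorine or the amino link accounts for the higher number of compound 3, which a plain phenylamino or a 4-chlorophenyl group would separate. Going by these compounds, it also remains open how a longer chain, such as ethyl or propyl, would fare here.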